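Capping the hydroxy group of compound 2 as a benzoyl ester

The source may hold more compounds than are shown below. What is called first, only, known or untested is meant among the compounds shown, and "the series" means these compounds.

Three compounds of the series have been run in an assay on nucleic acid for inhibition of Nucleic Acid, read by fluorescence, tested at 100 uM; on this read-out higher numbers stand for more inhibition at the one concentration tested (going by the name of the read-out) and lower numbers for less inhibition. Compound 2 `OC1CCCCC1n1cc(CN2CCN(c3ccccc3)CC2)nn1` gives 47%, the highest of the three numbers. Compound 1 `CCCCN(CCCC)Cc1cn(CC(O)COCc2ccccc2)nn1` gives 6% in this assay, and compound 3 `CCOC(=O)C1CCCN(Cc2cn(CC(O)COC(=O)c3ccccc3)nn2)C1` gives 6%; both sit beyond the scatter below compound 2. Compound 4 `O=C(OC1CCCCC1n1cc(CN2CCN(c3ccccc3)CC2)nn1)c1ccccc1` is next to be measured. It differs from compound 2 in one place: benzoyl in place of hydrogen on an oxygen on a saturated carbon, that is hydroxy to benzoyloxy. Among the compounds with values here, no two measured compounds differ in a single place, so no measured step guides the expectation. The step in this assay is expected to be small, a number 7 percentage points lower from compound 2 to compound 4 (within the scatter), a slight drop not beyond the scatter. Compound 4 is therefore estimated at 40%, within a range of 15% to 65%.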

Compound 4, a percentage reported as inhibition, at one concentration (the size of the read-out at that concentration, not a potency): 21%
Compound 4: middle estimate off by 19 percentage points, on the high side; the range from low to high includes it.
By their numbers in this assay, from the lowest: compounds 1 and 3 (each within the scatter of the next); then compound 4; then compound 2.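

In this assay, within the data shown here, hydroxy to benzoyloxy gives a number 26 percentage points lower from compound 2 to compound 4 (beyond the scatter) and so supplies the first measured single change. The oxygen on the saturated carbon is therefore a position where the benzoyl group costs inhibition, although compound 4 keeps part of it at the one concentration tested. Nothing measured here bears on the reason for the drop.

Open, as far as these compounds go, is whether the loss follows the benzoyl group or any capping of this oxygen: a smaller acetyl ester or a methyl ether would separate the two. Also open, from the compounds shown here alone, is whether an amine could stand in for the hydroxy group.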